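Bromo for Ethynyl on the Anilino Ring

The source may report more compounds than this note shows. Statements on the series, on what has been measured and on what is new or still open speak of the compounds shown alone.

Among the compounds with values here, compound 2 `C#Cc1cccc(Nc2ncnc3cc(OC)c(OCCCCC(=O)Nc4ccc(S(N)(=O)=O)cc4)cc23)c1` gives 17700 nM in a functional assay on A-431 cells (Homo sapiens) for antiproliferative activity, read by MTT assay, with a stated time of 72 h (on this read-out higher numbers stand for weaker inhibition and lower numbers for stronger inhibition), the higher of the two numbers measured so far; compound 1 `COc1cc2ncnc(Nc3ccc(Cl)c(C(F)(F)F)c3)c2cc1OCCCCC(=O)Nc1ccc(S(N)(=O)=O)cc1` gives 3910 nM. Compound 3 `COc1cc2ncnc(Nc3cccc(Br)c3)c2cc1OCCCCC(=O)Nc1ccc(S(N)(=O)=O)cc1` differs from compound 2 by bromo in place of ethynyl on an aromatic carbon. Within the data shown here, no measured step changes this group on its own; the only step seen, a 4.5-fold higher number from compound 1 to compound 2 (0.66 log units; beyond the scatter), swaps the whole anilino ring and offers no direct guide. Compound 3 is therefore expected to show a step of a 1.5-fold lower number from compound 2 to compound 3 (0.17 log units; within the scatter) that need not exceed the scatter. In this assay compound 3 is estimated at 12000 nM, ranging from 4000 nM to 35000 nM.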

Compound 3, half-maximal inhibitory concentration: 9750 nM
For compound 3 the middle estimate is 1.2-fold (0.09 log units) above the measured one; measured number inside the range.
By their numbers in this assay, from the lowest: compound 1; then compounds 3 and 2 (each within the scatter of the next).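

In this assay, within the data shown here, this is the first change confined to this one group, and a 1.8-fold lower number from compound 2 to compound 3 (0.26 log units; within the scatter) does not separate bromo from ethynyl on this aromatic carbon. With a 2.5-fold higher number from compound 1 to compound 3 (0.40 log units; beyond the scatter), the 3-bromophenyl ring, like the 3-ethynylphenyl ring, stays on the weaker side of the 4-chloro-3-(trifluoromethyl)phenyl ring. Nothing available bears on what lies behind these numbers. Open, going by these compounds, is whether a small substituent such as fluoro, or a larger one such as an amine or a carboxylic acid, at this place would give a step beyond the scatter.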